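A Phenyl for a Thiophene on a Compound Without Measured Activity

A few compounds are considered here, and "the series" means these few. Any claim that something is new, unique, unknown or untested is made for them only; others in the source may bear on it.

compound 1, `CC1CCCc2c1nc(N)c(C#N)c2-c1cccn1C`: > 100000 nM
compound 2, `Cn1cccc1-c1cc(-c2cccs2)nc(N)c1C#N`: > 100000 nM
compound 3, `Cn1cccc1-c1cc(-c2cccs2)[nH]c(=O)c1C#N`: > 100000 nM

Within the data shown here, all three compounds measured so far were tested in a functional assay on SF-539 cells (Homo sapiens) for inhibition, read by sulforhodamine B assay, with a stated time of 48 h; on this read-out higher numbers stand for weaker inhibition of growth and lower numbers for stronger inhibition of growth. Compound 3 stands exactly where the other two stand: its result of > 100000 nM is a limit of the assay, not a measured number. That every result so far is such a limit is shown by the limit of > 100000 nM in this assay, at which 3 of the 3 values shown sit; no compound in this set has a numerical value, and so no compound can be called stronger or weaker than another.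

Compound 4, `Cn1cccc1-c1cc(-c2ccccc2)[nH]c(=O)c1C#N`, has not yet been measured. It differs from compound 3 in a single place: phenyl in place of thiophen-2-yl on an aromatic carbon. Among the measured compounds shown here, no two measured compounds differ in one place, so there is no measured step to lean on. For the measured compounds named here, the only guide is that compound 1, compound 2 and compound 3, though they carry different groups, all sit at the same limit.

The step from compound 3 to compound 4 is therefore expected to be a number no higher from compound 3 to compound 4 (the limit leaves the size open), meaning no change beyond the scatter. For compound 4 the estimate is 100000 nM, with a range from 30000 nM to 300000 nM, and most likely the assay will once more report only a limit.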

Compound 4, concentration for 50% growth inhibition: > 100000 nM
Compound 4 gave a limit, no number (the forecaster's own chance of this, stated with the estimate: 85%); the middle value lies on the limit itself.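

In this assay compound 3 and compound 4 each give only a limit, so the change from thiophen-2-yl to phenyl cannot be read as a step: the limit of > 100000 nM in this assay, at which 4 of the 4 values shown sit.

On these data alone, how strongly any of these four compounds inhibits growth, and whether phenyl in place of thiophen-2-yl changes that strength at all, stays open.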